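The compounds below may be only part of what the source reports. "The series", "measured", "known", "first", "only" and "open" are said of these compounds alone.

Measured in a functional assay on HeLa cells (Homo sapiens) for inhibition, read by MTT assay, with a stated time of 48 h; on this read-out lower numbers stand for stronger inhibition and higher numbers for weaker inhibition:
Compound 1 `CS(=O)(=O)c1ccc(-c2nc3ccccn3c2Sc2ccccc2)cc1`: 70600 nM
Compound 2 `Cc1ccc(-c2nc3ccccn3c2Sc2ccccc2)cc1`: 86700 nM
Compound 3 `c1ccc(Sc2c(-c3cccc4ccccc34)nc3ccccn23)cc1`: 33100 nM

Compound 2 cannot be separated from compound 1, while compound 3 gives a lower number, beyond the scatter. Compound 4 `C(=C/c1nc2ccccn2c1Sc1ccccc1)\c1ccccc1` puts 2-phenylethenyl in place of 4-methylphenyl on an aromatic carbon. Among the compounds with values here, only one measured step bears on this group, a 1.2-fold higher number from compound 1 to compound 2 (0.09 log units; within the scatter), and it changes only a substituent on the phenyl ring. Compound 2 differs from compound 3 in this same group. Compound 3 gives 33100 nM, so a replacement of the whole group may lower the number somewhat. Overall, no change beyond the scatter is expected in this assay. The expected step is a 1.4-fold lower number from compound 2 to compound 4 (0.16 log units; within the scatter). Compound 4 is estimated at 60000 nM, with an expected range of 25000 nM to 130000 nM.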

Compound 4, half-maximal inhibitory concentration: 35500 nM
The estimate for compound 4 lay 1.7-fold (0.23 log units) above the measured number; measured number inside the range.
By their numbers in this assay, from the lowest: compounds 3, 4, 1 and 2 (each within the scatter of the next, the first and the last beyond it).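

In this assay, putting 2-phenylethenyl in place of 4-methylphenyl gives a 2.4-fold lower number from compound 2 to compound 4 (0.39 log units; beyond the scatter), whereas the earlier change of a substituent on the phenyl ring stayed within the scatter. Replacing the whole group at this aromatic carbon can therefore move the number, and compound 4 at 35500 nM stands within the scatter of compound 3 at 33100 nM. Nothing available here accounts for this step. As far as these compounds go, whether the double bond itself matters remains open, as a saturated 2-phenylethyl group here would show. So does the effect of an amine or a carboxylic acid at this carbon.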